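Aromatic ring restored where cyclohexyl sat

The source may hold more compounds than are shown below. What is called first, only, known or untested is meant among the compounds shown, and "the series" means these compounds.

Measured so far in this series:
compound 1 `COc1ccc(-c2ccc3c(NCCCNCc4cccc(OC)c4O)ccnc3c2)cc1`: 237 10^-6 cm/s
compound 2 `COc1cccc(CNCCCNc2ccnc3cc(C4CCCCC4)ccc23)c1O`: 23 10^-6 cm/s
compound 3 `COc1ccc(F)cc1CNCCCNc1ccnc2cc(C3CCCCC3)ccc12`: 23 10^-6 cm/s

All three numbers come from an ADME assay for permeability, using PAMPA, with a stated time of 30 min, at pH 7.4; a higher number here means that the compound crosses the layer faster, a lower number that the compound crosses the layer more slowly. Compound 2 stands level with compound 3 at the digits printed, and the two together are the lowest of the three values; the nearest neighbour of compound 2 is compound 3, with no change at the digits printed from compound 2 to compound 3 (within the scatter), and the furthest is compound 1, reached through a 10-fold lower number from compound 1 to compound 2 (1.01 log units; beyond the scatter) read in reverse.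

Compound 4 `COc1cccc(CNCCCNc2ccnc3cc(-c4ccc(F)cc4)ccc23)c1O` has not yet been measured. It differs from compound 2 by 4-fluorophenyl in place of cyclohexyl on an aromatic carbon. Of the measured steps, the one that bears on this change is a 10-fold lower number from compound 1 to compound 2 (1.01 log units; beyond the scatter), which made the opposite exchange, an aromatic ring giving way to cyclohexyl, and was large. The other step, no change at the digits printed from compound 2 to compound 3 (within the scatter), touches a different part of the molecule and says nothing here. Compound 4 is therefore expected to move upward by a large step, a 6.5-fold higher number from compound 2 to compound 4 (0.81 log units; beyond the scatter), though 4-fluorophenyl is not the same ring as 4-methoxyphenyl. Compound 4 is estimated at 150 10^-6 cm/s, within a range from 50 10^-6 cm/s to 400 10^-6 cm/s.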

Compound 4, apparent permeability: 237 10^-6 cm/s
Compound 4: middle estimate off by 1.6-fold (0.20 log units), on the low side, and the stated range covers the measured number.
By their numbers in this assay, from the lowest: compounds 2 and 3 (each within the scatter of the next); then compounds 1 and 4 (each within the scatter of the next).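

Putting 4-fluorophenyl where cyclohexyl sat gave a 10-fold higher number from compound 2 to compound 4 (1.01 log units; beyond the scatter) in this assay and so showed that the earlier fall could be reversed at this position with a different aromatic ring. The substituent on that ring counted for little here: no change at the digits printed from compound 1 to compound 4 (within the scatter) came with fluoro in place of methoxy on an aromatic carbon. Among these compounds, the two aromatic rings at this position are not told apart, while the cyclohexyl of compound 2 stands well apart from both, and no measurement shown gives a reason for this.

The compounds shown leave open whether a pyridine ring or a piperidine ring at this position would follow the aromatic rings or cyclohexyl. They also leave open whether 4-fluorophenyl would keep its number alongside the 5-fluoro-2-methoxyphenyl group of compound 3.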